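Benzothiophene for chlorophenyl on the tertiary carbinol core

The source may hold more compounds than are shown below. What is called first, only, known or untested is meant among the compounds shown, and "the series" means these compounds.

Measured so far:
compound 1 `OC(c1ccc(Cl)cc1)(c1ccc(C(F)(F)F)cc1)c1cccnc1` — 56400 nM
compound 2 `COc1ccc(C(O)(c2ccc(Cl)cc2)c2cccnc2)cc1` — 68100 nM

For the measured compounds named here, in an ADME assay on L6 cells (Rattus norvegicus) for cytotoxicity, read by resazurin assay, with a stated time of 72 h (on this read-out higher numbers stand for weaker inhibition and lower numbers for stronger inhibition), compound 1 gives 56400 nM and compound 2 gives 68100 nM; the only step known, a 1.2-fold higher number from compound 1 to compound 2 (0.08 log units; within the scatter), lies within the scatter, so compound 1 stands level with its one neighbour. Compound 3 `OC(c1ccc(C(F)(F)F)cc1)(c1cccnc1)c1cc2ccccc2s1` differs from compound 1 by 1-benzothiophen-2-yl in place of 4-chlorophenyl on a saturated chain carbon bound to two aromatic carbons and an oxygen on a saturated carbon. Going by the values given here, no measured step touches that change; the one known step concerns a different place on the core and was flat. With nothing to argue for movement, compound 3 is expected to stay near compound 1, a step of a 1.1-fold lower number from compound 1 to compound 3 (0.05 log units; within the scatter). Compound 3 is thus estimated at 50000 nM, with a range of 20000 nM to 130000 nM.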

Compound 3, half-maximal inhibitory concentration: 58700 nM
Compound 3: middle estimate off by 1.2-fold (0.07 log units), on the low side, within the range that was stated.
By their numbers in this assay, from the lowest: compounds 1, 3 and 2 (each within the scatter of the next).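

In this assay the place on a saturated chain carbon bound to two aromatic carbons and an oxygen on a saturated carbon takes 1-benzothiophen-2-yl in place of 4-chlorophenyl with a 1.0-fold higher number from compound 1 to compound 3 (0.02 log units; within the scatter) and so reads flat for this change. A second place on the shared core thus joins the methoxy for trifluoromethyl step as flat, even though the entering group adds a five-membered aromatic ring with 1 hetero atom. Nothing available explains this flatness. Going by these compounds, whether an amine or a carboxylic acid in the same place would move the number remains open.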